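This account rests on a few compounds, and the source may have more. Where it says the series, first, only, none or still open, it means among the compounds named here.

In a physicochemical assay for metabolic stability, read by HPLC (on this read-out lower numbers stand for a shorter-lived compound and higher numbers for a longer-lived compound), compound 3 (`Cc1cn([C@H]2C[C@H](N=[N+]=[N-])[C@@H](COP(=O)(O)Oc3ccc(C#N)cc3)O2)c(=O)[nH]c1=O`) gives 7.08 h as the lowest of three numbers, against compound 2 (`O=c1ccn([C@H]2CC[C@@H](COP(=O)(O)Oc3ccncc3)O2)c(=O)[nH]1`) at 23.6 h and compound 1 (`O=c1ccn([C@H]2CC[C@@H](COP(=O)(O)Oc3cccnc3)O2)c(=O)[nH]1`) at 50.2 h on a core unlike that of compound 3. The next change leads to compound 4 (`Cc1cn([C@H]2C[C@H](N=[N+]=[N-])[C@@H](COP(=O)(O)Oc3cncc(Cl)c3)O2)c(=O)[nH]c1=O`) and reads (5-chloropyridin-3-yl in place of 4-cyanophenyl on an oxygen); in words, 5-chloropyridin-3-yl in place of 4-cyanophenyl on an oxygen.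

Going by the values given here, no measured step makes this exchange on the core of compound 3. The nearest evidence is a 2.1-fold lower number from compound 1 to compound 2 (0.33 log units; beyond the scatter) as a modest step, which shows that a change within the pyridinyl group can move the number beyond the scatter. That step involves neither chlorine nor the 4-cyanophenyl group, so it gives only a rough size and no firm direction. A small step is therefore expected, lower if anything and probably not clearly beyond the scatter. The expected change is a 1.4-fold lower number from compound 3 to compound 4 (0.15 log units; within the scatter) as a working estimate. The estimate for compound 4 is 5 h with an expected range of 2 h to 12 h.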

Compound 4, half-life: 7.27 h
The estimate for compound 4 lay 1.5-fold (0.16 log units) below the measured number, and the stated range covers the measured number.
By their numbers in this assay, from the lowest: compounds 3 and 4 (each within the scatter of the next); then compound 2; then compound 1.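

In this assay, putting 5-chloropyridin-3-yl in place of 4-cyanophenyl on an oxygen gives a 1.0-fold higher number from compound 3 to compound 4 (0.01 log units; within the scatter), so the two groups cannot be told apart on this read-out on the core of compound 3. Going by these compounds alone, the only earlier step, a 2.1-fold lower number from compound 1 to compound 2 (0.33 log units; beyond the scatter), lies beyond the scatter but belongs to another core; the new step shows that, on the core of compound 3, replacing a ring of carbon only with a ring holding one hetero atom need not separate two compounds. Nothing available here accounts for this result.

On these data alone, whether an aromatic group carrying an amine or a carboxylic acid on this oxygen would stay within the scatter of compound 3 remains open. Also open, as far as these compounds go, is whether the 5-chloropyridin-3-yl group would read the same on the core of compound 1.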